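The compounds below may be only part of what the source reports. "The series", "measured", "known", "first", "only" and "open" are said of these compounds alone.

The shared core of this small set is that of compound 1 `NCCC[C@@H]1CCO[C@H](c2ccccc2)O1`, which in an assay for displacement of a labelled ligand from Sigma non-opioid intracellular receptor 1 (Cavia porcellus), read by scintillation counting (on this read-out higher numbers stand for weaker inhibition and lower numbers for stronger inhibition), gives 167 nM. Compound 2 `CNCCC[C@@H]1CCO[C@H](c2ccccc2)O1` carries a methyl in place of hydrogen on the amine nitrogen, and in this assay compound 2 gives 327 nM. Going by the values given here, the single step between them reads a 2.0-fold higher number from compound 1 to compound 2 (0.29 log units; within the scatter). Among the compounds with values here, of the two numbers measured so far, compound 2 stands highest, with compound 1 nearest to it, the two lying within the scatter of each other. Compound 3 `c1ccc(CNCCC[C@@H]2CCO[C@H](c3ccccc3)O2)cc1` differs from compound 2 by phenyl in place of hydrogen on a saturated chain carbon bound to an amine nitrogen. Within the data shown here, the one measured step that touches the same amine end of the chain is that from compound 1 to compound 2, and it stayed within the scatter; no step in the set introduces a phenyl at this place, so there is no direct precedent for the size of the change. The account therefore expects the step from compound 2 to compound 3 to be a 4.7-fold lower number from compound 2 to compound 3 (0.67 log units; beyond the scatter), toward a lower number, with wide bounds. Compound 3 is estimated at 70 nM in this assay, within a range from 15 nM to 330 nM.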

Compound 3, inhibition constant: 164 nM
Beside the measured number, compound 3's estimate is 2.3-fold (0.37 log units) below it; measured number inside the range.
By their numbers in this assay, from the lowest: compounds 3, 1 and 2 (each within the scatter of the next).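

In this assay, the amine nitrogen now carries a much larger group than before without a change beyond the scatter: the step reads a 2.0-fold lower number from compound 2 to compound 3 (0.30 log units; within the scatter), and measured against the free amine it reads a 1.0-fold lower number from compound 1 to compound 3 (0.01 log units; within the scatter). Until now the only change at this end of the chain was a methyl, so the set could not show whether a whole aromatic ring, six heavy atoms of carbon in place of a hydrogen on the saturated chain carbon bound to the amine nitrogen, would leave the number within the scatter; among these three compounds, hydrogen, methyl and benzyl on the nitrogen cannot be told apart. No measurement shown here bears on why this is so.

From the compounds shown here alone, how far this holds for other groups on the nitrogen stays open, for instance a phenethyl, a cyclohexylmethyl or a chlorobenzyl group. All three compounds also keep a hydrogen on the nitrogen, so what a dimethylamino group or a piperidine at the end of the chain would give is left open as well.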